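The source may hold more compounds than are shown below. What is called first, only, known or untested is meant among the compounds shown, and "the series" means these compounds.

Compound 1 `CCN(CC)C(=O)Cn1c(=O)c(-c2ccc(OC)cc2)cc2c(OC)cc(OC)cc21` and compound 2 `COc1ccc(-c2cc3c(OC)cc(OC)cc3n(CCCC#N)c2=O)cc1` share one core and differ only in the chain on an aromatic nitrogen. Within the data shown here, in a functional assay on A549 cells (Homo sapiens) for cytotoxicity, read by colorimetric assay and MTT assay (on this read-out lower numbers stand for stronger inhibition and higher numbers for weaker inhibition), compound 1 gives 10000 nM and compound 2 gives 10000 nM as well, so compound 2 stands level with its only measured neighbour. Compound 3 `COC(=O)CCn1c(=O)c(-c2ccc(OC)cc2)cc2c(OC)cc(OC)cc21` keeps the shared core, and its difference from compound 2 is methoxycarbonyl in place of cyanomethyl on a saturated chain carbon, two bonds along the chain from an aromatic nitrogen in one place: methoxycarbonyl in place of cyanomethyl on a saturated chain carbon, two bonds along the chain from an aromatic nitrogen. Among the measured compounds shown here, the one measured step that bears on this, no change at the digits printed from compound 1 to compound 2 (within the scatter) on the same chain, stayed within the scatter. A single step is thin evidence, but it offers no reason to expect movement. In this assay the expected change is no change at the digits printed from compound 2 to compound 3 (within the scatter) and no shift beyond the scatter is anticipated. Compound 3 is estimated at 10000 nM with an expected range from 4000 nM to 20000 nM on this measure.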

Compound 3, half-maximal inhibitory concentration: 10000 nM
Beside the measured number, compound 3's estimate shows no gap at the digits printed, and the stated range covers the measured number.
By their numbers in this assay, from the lowest: compounds 1, 2 and 3 (each within the scatter of the next).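

In this assay, methoxycarbonyl in place of cyanomethyl on a saturated chain carbon, two bonds along the chain from an aromatic nitrogen, gives no change at the digits printed from compound 2 to compound 3 (within the scatter). Setting (methoxycarbonyl)methyl in place of diethylcarbamoyl on a saturated chain carbon bound to an aromatic nitrogen gives no change at the digits printed from compound 1 to compound 3 (within the scatter), so where a single pair stood before, three different chains on this nitrogen now cannot be told apart by this read-out. Nothing available explains this flat result.

On these data alone, what a chain ending in a carboxylic acid or an amine would do at this position remains open. So does the effect of a longer chain, and whether any change here can move the number at all.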